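Triazolothiadiazine series: halophenyl exchange at the imine carbon

The source may hold more compounds than are shown below. What is called first, only, known or untested is meant among the compounds shown, and "the series" means these compounds.

Measured so far:
compound 1 `COc1ccc2cc(C(C)c3nnc4n3N=C(c3ccc(Br)cc3)CS4)ccc2c1`: 9300 nM
compound 2 `COc1ccc2cc(C(C)c3nnc4n3N=C(c3ccc(Cl)cc3Cl)CS4)ccc2c1`: 10700 nM
compound 3 `CC(C)Cc1ccc(C(C)c2nnc3n2N=C(c2ccc(Cl)cc2Cl)CS3)cc1`: 7500 nM

All three numbers come from a functional assay on Huh-7 cells (Homo sapiens) for inhibition, read by sulforhodamine B assay, with a stated time of 72 h (on this read-out lower numbers stand for stronger inhibition and higher numbers for weaker inhibition), and lie within the scatter of one another, so no order among compounds 1, 2 and 3 is claimed. Compound 2 and compound 1 differ in one place: 4-bromophenyl in place of 2,4-dichlorophenyl on a carbon with a double bond to nitrogen. That change gave a 1.2-fold lower number from compound 2 to compound 1 (0.06 log units; within the scatter). Compound 3 and compound 2 carry different cores; the difference between the two cores is not broken down here.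

Compound 4 `CC(C)Cc1ccc(C(C)c2nnc3n2N=C(c2ccc(Br)cc2)CS3)cc1` has not yet been run in this assay. It relates to compound 3 by the same change, (4-bromophenyl in place of 2,4-dichlorophenyl on a carbon with a double bond to nitrogen). Among the measured compounds shown here, on the core of compound 2 this change moved the number only slightly, so compound 4 is expected to sit close to compound 3, with an expected step of a 1.2-fold lower number from compound 3 to compound 4 (0.06 log units; within the scatter), because the only measured precedent is a 1.2-fold lower number from compound 2 to compound 1 (0.06 log units; within the scatter). The estimate for compound 4 in this assay is 6500 nM, with a range from 3000 nM to 14000 nM.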

Compound 4, half-maximal inhibitory concentration: 4900 nM
Compound 4: the middle estimate sits 1.3-fold (0.12 log units) above what was measured; the range from low to high includes it.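

In this assay, 4-bromophenyl in place of 2,4-dichlorophenyl on the carbon with a double bond to nitrogen gives a 1.5-fold lower number from compound 3 to compound 4 (0.18 log units; within the scatter), so on this second core the step again stays within the scatter. Set side by side, the two steps do not differ: the same change on two cores in this assay, a 1.2-fold lower number (0.06 log units; within the scatter) from compound 2 to compound 1 and a 1.5-fold lower number (0.18 log units; within the scatter) from compound 3 to compound 4, 1.3-fold (0.12 log units) apart, within the scatter of two such steps

The change thus carries across these two cores with no detectable difference in size, but neither step is large enough to show that 4-bromophenyl is better or worse than 2,4-dichlorophenyl, and two cores do not establish a rule for the whole series.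

The compounds shown carry only halogen-bearing phenyl groups on the carbon with a double bond to nitrogen, so it remains open whether an unsubstituted phenyl, an amine or a carboxylic acid there would move the number beyond the scatter. Also open, on these data alone, is whether the same change behaves alike on any core other than those of compound 1 and compound 4.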